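The source may hold more compounds than are shown below. What is called first, only, known or untested is meant among the compounds shown, and "the series" means these compounds.

Measured so far in a functional assay on SN12C cells (Homo sapiens) for cytotoxicity, read by sulforhodamine B assay, with a stated time of 48 h, tested at 100 uM; a higher number here means a weaker effect of the compound at the concentration tested, a lower number a stronger effect: compound 1 `COc1ccc(-c2cc(/C=C/C(=O)c3ccc(N)cc3)[nH]n2)cc1` gives -78%; compound 2 `COc1cc(-c2cc(/C=C/C(=O)c3ccc(N)cc3)[nH]n2)cc(OC)c1OC` gives -86%.

Of the two numbers, compound 2 has the lower one, but its gap to compound 1 lies within the scatter, so the two readings say the same thing. Compound 3 `COc1ccc(-c2cc(/C=C/C(=O)c3ccc(N)cc3)[nH]n2)cc1OC` has not been tested. The change from compound 2 to compound 3 is hydrogen in place of methoxy on an aromatic carbon. Going by the values given here, with no step between measured compounds to go on, and both readings so close, no step beyond the scatter is expected in this assay; the estimated step is a number 6 percentage points higher from compound 2 to compound 3 (within the scatter). Compound 3 is estimated at -80%, between -95% and -60%.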

Compound 3, a percentage reported as activity, at one concentration (the size of the read-out at that concentration, not a potency): -90%
The estimate for compound 3 lay 10 percentage points above the measured number; measured number inside the range.
By their numbers in this assay, from the lowest: compounds 3, 2 and 1 (each within the scatter of the next, the first and the last beyond it).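

In this assay, hydrogen in place of methoxy gives a number 4 percentage points lower from compound 2 to compound 3 (within the scatter) and so leaves the reading within the scatter: this position, ortho to a methoxy group and meta to a large group, takes either substituent. Methoxy in place of hydrogen on an aromatic carbon gives a number 12 percentage points lower from compound 1 to compound 3 (beyond the scatter) as the first step in the series beyond the scatter, though a modest one. No measurement on hand explains either step.

Going by these compounds, whether hydroxy, fluorine or ethoxy at this position would hold the reading stays open. So does replacing the amino group of the shared core with an acetamide.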